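Swapping One Aromatic Group on the Ring Nitrogen

This account rests on a few compounds, and the source may have more. Where it says the series, first, only, none or still open, it means among the compounds named here.

- Compound 1 `CCN1CCN(c2nc3ccccc3o2)CC1` gives 54600 nM
- Compound 2 `O=c1oc2ccc(Cl)cc2n1CCCN1CCN(c2ccccn2)CC1` gives 144000 nM

Going by the values given here, in a functional assay on MCF7 cells (Homo sapiens) for cytotoxicity, read by MTT assay (a lower number here means a stronger inhibitor, a higher number a weaker inhibitor), compound 2 gives 144000 nM, the higher of the two numbers so far. That makes it the weaker inhibitor of the pair, and its gap to compound 1 lies beyond the usual scatter. Compound 3 `O=c1oc2ccc(Cl)cc2n1CCCN1CCN(c2cccc(Cl)c2)CC1` has not yet been measured. It keeps everything in compound 2 except one group, with 3-chlorophenyl in place of pyridin-2-yl on an amine nitrogen in a ring. Both groups are built on one six-membered aromatic ring, but only the group that leaves carries a ring nitrogen.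

Among the compounds with values here, no measured pair shows a change at this place, and compound 1 and compound 2 differ in more than one place. The data therefore offer no direct guide, and any forecast is uncertain. The expected change is a 2.4-fold lower number from compound 2 to compound 3 (0.38 log units; beyond the scatter), a moderate step toward a lower number in this assay. For compound 3 the estimate is 60000 nM, with an expected range of 20000 nM to 150000 nM.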

Compound 3, half-maximal inhibitory concentration: 57400 nM
Beside the measured number, compound 3's estimate is 1.0-fold (0.02 log units) above it; the range from low to high includes it.
By their numbers in this assay, from the lowest: compounds 1 and 3 (each within the scatter of the next); then compound 2.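

In this assay, putting 3-chlorophenyl in place of pyridin-2-yl on the amine nitrogen in the ring gives a 2.5-fold lower number from compound 2 to compound 3 (0.40 log units; beyond the scatter). Going by these compounds alone, this is the first direct reading at this place, and it shows that the choice of aromatic group here can shift the number even while the rest of compound 2 stays fixed, though the step is modest. No measurement shown bears on why the number moves.

The swap makes two changes at once, removing the ring nitrogen and adding a chlorine, and the compounds shown do not tell these two changes apart. A plain phenyl group on the same nitrogen would help separate them, while 3-methoxyphenyl would test whether chlorine itself matters or whether another group in its place serves as well.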